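Sulfonamide aryl swap: from dimethylphenyl to methoxyphenyl

The source may report more compounds than this note shows. Statements on the series, on what has been measured and on what is new or still open speak of the compounds shown alone.

Measured compounds:
compound 1, `O=C1NCCN1c1ccc(S(=O)(=O)Nc2ccc3[nH]ccc3c2)cc1`, 170 nM in a functional assay on MCF7 cells (Homo sapiens) for antiproliferative activity, read by sulforhodamine B assay, with a stated time of 48 h; a higher number here means a weaker inhibitor, a lower number a stronger inhibitor
compound 2, `Cc1ccc(NS(=O)(=O)c2ccc(N3CCNC3=O)cc2)cc1C`, 230 nM
compound 3, `CCCCCc1ccc(NS(=O)(=O)c2ccc(N3CCNC3=O)cc2)cc1`, > 1000 nM

Compound 2 gives 230 nM, and compound 1 gives 170 nM; these two numbers lie within the usual scatter of each other, so neither can be called stronger. Compound 3 reaches only the limit of the assay, > 1000 nM, and so gives no number (the limit of > 1000 nM in this assay, at which 1 of the 3 values shown sits).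

Compound 4, `COc1ccccc1NS(=O)(=O)c1ccc(N2CCNC2=O)cc1`, differs from compound 2 by 2-methoxyphenyl in place of 3,4-dimethylphenyl on a sulfonamide nitrogen. Among the measured compounds shown here, no measured pair shows this kind of exchange, so its effect is uncertain; a modest weakening is expected, close to the scatter, as a 1.7-fold higher number from compound 2 to compound 4 (0.24 log units; within the scatter). Compound 4 is estimated at 400 nM, expected between 150 nM and 1500 nM.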

Compound 4, half-maximal inhibitory concentration: 770 nM
Compound 4: the middle estimate sits 1.9-fold (0.28 log units) below what was measured; the range from low to high includes it.
By their numbers in this assay, from the lowest: compounds 1 and 2 (each within the scatter of the next); then compound 4. At a limit, above all of these: compound 3.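

In this assay, among the compounds shown here, the group on the sulfonamide nitrogen matters: 2-methoxyphenyl in place of 3,4-dimethylphenyl gives a 3.3-fold higher number from compound 2 to compound 4 (0.52 log units; beyond the scatter), the first change at one place that can be read here. This position therefore responds to the exchange, even though both groups hold one six-membered aromatic ring of carbon only. Nothing in the data shown explains the size of this step.

As far as these compounds go, it remains open whether the methoxy group or the absence of the two methyl groups accounts for the change. From the compounds shown here alone, how a phenyl ring carrying an amine or a carboxylic acid would behave on this nitrogen also remains open.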